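Swapping the anilino arm for a chlorophenyl arm

The compounds below may be only part of what the source reports. "The series", "measured", "known", "first", "only" and "open" are said of these compounds alone.

Compound 1 `O=C(NCc1ccncc1)Nc1ccc(S(=O)(=O)Nc2ccccc2)cc1` is a urea that was tested in an assay on isolated protein for activation of Nicotinamide phosphoribosyltransferase (Homo sapiens); a higher number here means that more compound is needed for the effect, a lower number that less compound is needed. In this assay compound 1 gives 410 nM, the lowest of the two numbers measured here. Compound 3 `CCOC(=O)c1ccc(N/C(=N\C#N)NCc2ccncc2)cc1` gives 41400 nM in this assay, a weaker result by a margin that lies well beyond the usual scatter. Compound 2 `CCOC(=O)c1ccc(NC(=O)NCc2ccnnc2)cc1` only reaches a limit of the assay, > 100000 nM, and so gives no number at all (the limit of > 100000 nM in this assay, at which 1 of the 3 values shown sits).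

Compound 4 `O=C(NCc1ccncc1)Nc1ccc(S(=O)(=O)c2cccc(Cl)c2)cc1` has not yet been measured. It differs from compound 1 in a single place: 3-chlorophenyl in place of anilino on a sulfonyl sulfur. Within the data shown here, no measured pair among the compounds above shows a change of this kind, so its size cannot be read from them. The step from compound 1 to compound 4 is expected to be small, a 2.0-fold higher number from compound 1 to compound 4 (0.29 log units; within the scatter), and likely within or only just beyond the scatter. In this assay compound 4 is therefore estimated to give about 800 nM, with a plausible range from 150 nM to 5000 nM.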

Compound 4, half-maximal effective concentration: 69 nM
The estimate for compound 4 lay 12-fold (1.06 log units) above the measured number; measured number below the stated range.
By their numbers in this assay, from the lowest: compound 4; then compound 1; then compound 3. At a limit, above all of these: compound 2.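

Replacing anilino with 3-chlorophenyl on a sulfonyl sulfur gives a 5.9-fold lower number from compound 1 to compound 4 (0.77 log units; beyond the scatter) in this assay, so this position responds clearly to the change. Compound 4 has no hydrogen-bond donor on this arm and still gives the lower number, which shows that the donor counted on the anilino arm of compound 1 is not needed for a low number here. Nothing measured here explains why the number falls.

The compounds shown cannot separate the effect of adding the chlorine from that of losing the anilino nitrogen, and a plain phenyl group on the sulfonyl sulfur would help to tell the two apart. From the compounds shown here alone, how the number responds to a non-aromatic group at this place, such as cyclohexyl or morpholine, also remains open.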